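A few compounds are considered here, and "the series" means these few. Any claim that something is new, unique, unknown or untested is made for them only; others in the source may bear on it.

Compound 2 `Oc1ccccc1CNc1ccc(-c2ccc(F)cc2)cc1` carries a shared core that also appears in compound 3 `Cc1ccccc1-c1ccc(NCc2ccccc2O)cc1` and compound 1 `O=[N+]([O-])c1ccc(NCc2ccccc2O)cc1`. In a functional assay on Jurkat cells (Homo sapiens) for activation, with a stated time of 24 h (a higher number here means that more compound is needed for the effect, a lower number that less compound is needed), compound 2 gives 3860 nM, and compound 3 gives 5220 nM, so the two stand within the scatter of each other, as the step of a 1.4-fold higher number from compound 2 to compound 3 (0.13 log units; within the scatter) shows. Compound 1 gives "not active" (no number reported) in this assay and offers no number. Compound 4 `CCCc1ccc(-c2ccc(NCc3ccccc3O)cc2)cc1` differs from compound 2 by propyl in place of fluoro on an aromatic carbon. Going by the values given here, the only measured step, from compound 2 to compound 3, swaps one aryl group for another and stays within the scatter, so no step beyond the scatter is expected here either. Compound 4 is therefore estimated at 4000 nM, in a range from 1500 nM to 10000 nM, which means an expected step of a 1.0-fold higher number from compound 2 to compound 4 (0.02 log units; within the scatter).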

Compound 4, half-maximal effective concentration: 2390 nM
Estimate against measurement, compound 4: 1.7-fold (0.22 log units) above; low and high end bracket the measured number.
By their numbers in this assay, from the lowest: compounds 4, 2 and 3 (each within the scatter of the next, the first and the last beyond it).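

Replacing fluoro with propyl on this aromatic carbon, para to a large group, gives a 1.6-fold lower number from compound 2 to compound 4 (0.21 log units; within the scatter) in this assay. The earlier step exchanged one whole aryl group for another, whereas this one keeps the ring and shows that a longer group at this place causes no shift beyond the scatter. Nothing available here offers an explanation for this result. Going by these compounds, whether an amine, a carboxylic acid or a chain longer than propyl at this place would also stay within the scatter remains open.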